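This account rests on a few compounds, and the source may have more. Where it says the series, first, only, none or still open, it means among the compounds named here.

Measured in a functional assay on LNCaP cells (Homo sapiens) for cytotoxicity; a higher number here means a weaker inhibitor, a lower number a stronger inhibitor:
- Compound 1 `CNC(=O)Nc1ccc(-c2nc(N3CC4CCC(C3)O4)c3cnn(C)c3n2)cc1`: 170 nM
- Compound 2 `CNC(=O)Nc1ccc(-c2nc(N3CC4CCC(C3)O4)c3cnn(CCO)c3n2)cc1`: 650 nM
- Compound 3 `CNC(=O)Nc1ccc(-c2nc(N3CC4CCC(C3)O4)c3cnn(C4CCC5(CC4)OCCCO5)c3n2)cc1`: 8 nM

Compound 3 has the lowest number of the three, and its steps to the other two lie beyond the scatter. The next structure, compound 4 `CNC(=O)Nc1ccc(-c2nc(N3CC4CCC(C3)O4)c3cnn(C4CCC(OC)(OC)CC4)c3n2)cc1`, keeps the shared core and differs only on an aromatic nitrogen of a five-membered aromatic ring with 2 nitrogen: a group of 10 heavy atoms (8 carbon, 2 oxygen; one six-membered non-aromatic ring of carbon only) in place of a group of 11 heavy atoms (9 carbon, 2 oxygen; one six-membered non-aromatic ring of carbon only, one six-membered non-aromatic ring with 2 hetero atoms), on an aromatic nitrogen.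

Going by the values given here, three measured steps concern this same nitrogen. They are the large 21-fold lower number from compound 1 to compound 3 (1.33 log units; beyond the scatter), the large 81-fold lower number from compound 2 to compound 3 (1.91 log units; beyond the scatter) and the modest 3.8-fold higher number from compound 1 to compound 2 (0.58 log units; beyond the scatter). They show that changes here can shift the number widely, but none compares two groups as alike as these. Both groups carry a six-membered non-aromatic ring of carbon only and 2 oxygen, so only a small step is expected, perhaps none beyond the scatter, and if anything upward. The expected step is a 1.8-fold higher number from compound 3 to compound 4 (0.24 log units; within the scatter). Compound 4 is estimated at 14 nM, with an expected range from 4 nM to 45 nM.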

Compound 4, half-maximal inhibitory concentration: 2 nM
Compound 4: the middle estimate sits 7.0-fold (0.85 log units) above what was measured, and the stated range ends above it.
By their numbers in this assay, from the lowest: compound 4; then compound 3; then compound 1; then compound 2.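

In this assay, the step to the group with one six-membered non-aromatic ring of carbon only, which keeps the 2 oxygen but loses the six-membered non-aromatic ring with 2 hetero atoms, still registers (a 4.0-fold lower number from compound 3 to compound 4 (0.60 log units; beyond the scatter)). This nitrogen therefore separates even two closely related groups, not only groups of very different size. Against the smaller groups, the steps grow larger still (an 85-fold lower number from compound 1 to compound 4 (1.93 log units; beyond the scatter); a 330-fold lower number from compound 2 to compound 4 (2.51 log units; beyond the scatter)), and no supporting measurement accounts for the difference between the two large groups.

The compounds shown do not tell whether the oxygen atoms matter on the carbon ring, since none carries a ketone, a hydroxyl or an amine there. They also leave open how a plain cyclohexyl group on this nitrogen would compare.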